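Notes on a piperidinyl-to-pyrrolidinyl amide exchange

This account rests on a few compounds, and the source may have more. Where it says the series, first, only, none or still open, it means among the compounds named here.

Compound 1 `CCn1c(/C=C2\SC(=O)N(CC(=O)N3CCCCC3)C2=O)nc2ccccc21` — in a functional assay on PC-3 cells (Homo sapiens) for inhibition, read by MTT assay, with a stated time of 48 h (a lower number here means a stronger inhibitor, a higher number a weaker inhibitor), compound 1 reads only as the limit > 50000 nM.
Compound 2 `Cn1c(/C=C2\SC(=O)N(CC(=O)N3CCCCC3)C2=O)nc2ccccc21` — compound 2 also sits at a limit, > 50000 nM.
Compound 3 `Cn1c(/C=C2\SC(=O)N(CC(=O)Nc3nc(-c4ccccc4)cs3)C2=O)nc2ccccc21` — compound 3 gives 39900 nM.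

Compound 1 stands as a limit, not a number, at the point described by the limit of > 50000 nM in this assay, at which 2 of the 3 values shown sit. The step that the two limits leave unreadable from compound 1 to compound 2 is unreadable. Within the data shown here, compound 3 holds the only numbered value and lies close to that limit.

Compound 4 `CCn1c(/C=C2\SC(=O)N(CC(=O)N3CCCC3)C2=O)nc2ccccc21` differs from compound 1 by pyrrolidin-1-yl in place of piperidin-1-yl on a carbonyl carbon. Among the measured compounds shown here, no measured step covers this exchange, and the single step between measured compounds that differ in one place cannot be sized. The expectation therefore rests on compound 1 remaining at its limit. The expected step is a step that the limit leaves unreadable from compound 1 to compound 4, none beyond the scatter. Compound 4 is estimated at 60000 nM, range 30000 nM to 150000 nM, most likely again only a limit.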

Compound 4, half-maximal inhibitory concentration: > 50000 nM
Compound 4: no number, only a limit (the forecaster's own chance of this, stated with the estimate: 75%); the middle value is on the limit's open side.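

Compound 1 and compound 4 both stand only as limits, so no step can be read for pyrrolidin-1-yl in place of piperidin-1-yl. How far these two compounds differ remains open, since most of the series sits at one limit: the limit of > 50000 nM in this assay, at which 3 of the 4 values shown sit.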